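The compounds below may be only part of what the source reports. "The series", "measured", "known", "first", "only" and "open" are said of these compounds alone.

Compound 1 `CC1=C(C(=O)Nc2ccccc2Cl)C(c2ccccc2Cl)NC(=O)N1` was tested in an ADME assay on Vero cells (Chlorocebus sabaeus) for cytotoxicity, read by XTT assay, with a stated time of 72 h (a lower number here means that less compound is tolerated, a higher number that more compound is tolerated), and gives "non-toxic" (no number reported), so no single number places it; it is simply recorded as tolerated. Compound 2 `CC1=C(C(=O)Nc2ccccc2Cl)C(c2cccc(Br)c2)NC(=O)N1` gives > 100000 nM in this assay, which is a limit of the assay and not a number. Compound 3 `CC1=C(C(=O)Nc2ccccc2Cl)C(c2cccc([N+](=O)[O-])c2)NC(=O)N1` likewise gives "non-toxic" (no number reported) in this assay. Among the three values shown stands (the limit of > 100000 nM in this assay, at which 1 of the 3 values shown sits), and none of them is a measured number, so no measured step between them can be described.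

Compound 4 `CC1=C(C(=O)Nc2ccccc2Cl)C(c2ccc([N+](=O)[O-])cc2)NC(=O)N1` differs from compound 1 by 4-nitrophenyl in place of 2-chlorophenyl on a saturated ring carbon. Since every value shown sits at or beyond the top of the range, no step beyond the scatter is expected in this assay in either direction. Compound 4 is therefore expected to give 100000 nM, estimated between 30000 nM and 300000 nM.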

Compound 4, half-maximal cytotoxic concentration: "non-toxic" (no number reported)
No number was reported for compound 4; no gap can be computed for the estimate.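

In this assay, among the compounds shown here, compound 1 and compound 4 are both recorded without a number, so no step between them can be read. The compounds shown leave open at what concentration, if any, each one harms these cells.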